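Swapping Trifluoromethyl for Phenyl on the Benzyl Arm

The source may report more compounds than this note shows. Statements on the series, on what has been measured and on what is new or still open speak of the compounds shown alone.

Compound 1, `COc1ccc(CNCCCNS(=O)(=O)c2cc(C(F)(F)F)cc(C(F)(F)F)c2)cc1OC`, gives 3800 nM in a functional assay on A2780 cells (Homo sapiens) for inhibition, read by MTT assay, with a stated time of 72 h; a lower number here means a stronger inhibitor of growth, a higher number a weaker inhibitor of growth.
Compound 2, `O=S(=O)(NCCCNCC1COc2ccccc2O1)c1cc(C(F)(F)F)cc(C(F)(F)F)c1`, gives 1500 nM.
Compound 3, `O=S(=O)(NCCCNCc1ccc(C(F)(F)F)cc1)c1cc(C(F)(F)F)cc(C(F)(F)F)c1`, gives 2800 nM.

All three compounds keep the same core and differ only in the group carried on the saturated chain carbon bound to the amine nitrogen. Compound 3 has the second highest of the three numbers: the step of a 1.4-fold lower number from compound 1 to compound 3 (0.13 log units; within the scatter) and the step of a 1.9-fold higher number from compound 2 to compound 3 (0.27 log units; within the scatter) both stay within the scatter, so compound 3 cannot be told apart from either neighbour with confidence. Within the data shown here, only the step of a 2.5-fold lower number from compound 1 to compound 2 (0.40 log units; beyond the scatter) is modest and beyond the scatter.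

Compound 4, `O=S(=O)(NCCCNCc1ccc(-c2ccccc2)cc1)c1cc(C(F)(F)F)cc(C(F)(F)F)c1`, differs from compound 3 by phenyl in place of trifluoromethyl on an aromatic carbon. The three measured steps all concern changes of the group on the same chain carbon, so they bear on the new step only loosely, and none of them exchanges trifluoromethyl for phenyl. Since those steps were modest or within the scatter, the step of a 1.3-fold lower number from compound 3 to compound 4 (0.10 log units; within the scatter) is expected to stay within the scatter, with no clear direction. Compound 4 is therefore estimated at 2200 nM, with a range from 700 nM to 7000 nM.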

Compound 4, concentration for 50% growth inhibition: 2600 nM
The estimate for compound 4 lay 1.2-fold (0.07 log units) below the measured number, within the range that was stated.
By their numbers in this assay, from the lowest: compounds 2, 4, 3 and 1 (each within the scatter of the next, the first and the last beyond it).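

In this assay, phenyl in place of trifluoromethyl gives a 1.1-fold lower number from compound 3 to compound 4 (0.03 log units; within the scatter) and leaves compound 3 and compound 4 impossible to tell apart. The earlier steps shown here exchanged the whole group on the chain carbon, whereas this one changes only a substituent on an aromatic carbon, para to a large group, and shows that a group of 4 heavy atoms with no ring and a group of 6 heavy atoms forming a six-membered aromatic ring give no readable difference at this position. No measurement shown explains this result.

On these data alone, whether a carboxylic acid or an amine on this same aromatic carbon would move the number beyond the scatter remains open. It is also unclear whether a longer chain joining the two nitrogens would do so.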